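A few compounds are considered here, and "the series" means these few. Any claim that something is new, unique, unknown or untested is made for them only; others in the source may bear on it.

Three measured compounds share a core joined through an amide to a chain that ends in a hydroxycarbamoyl group. Compound 1 `O=C(CCCCCCC(=O)Nc1nc2ccccc2s1)NO` gives 5.71 ug/mL in a functional assay on NCI-H460 cells (Homo sapiens) for cytotoxicity; on this read-out higher numbers stand for weaker inhibition and lower numbers for stronger inhibition. Compound 2 `CCOc1ccc2nc(NC(=O)CCCCC(=O)NO)sc2c1` gives 7.96 ug/mL in this assay, and compound 3 `CCOc1ccc2nc(NC(=O)CCCCCCC(=O)NO)sc2c1` gives 6.58 ug/mL. Compound 2 and compound 3 differ in their chains: hydroxycarbamoyl in place of 2-(hydroxycarbamoyl)ethyl on a saturated chain carbon, four bonds along the chain from a carbonyl carbon. The step of a 1.2-fold lower number from compound 2 to compound 3 (0.08 log units; within the scatter) is small. Compound 1 differs from compound 3 by hydrogen in place of ethoxy on an aromatic carbon, and the step of a 1.2-fold lower number from compound 3 to compound 1 (0.06 log units; within the scatter) is also small. Compound 4 `O=C(CCCCC(=O)Nc1nc2ccccc2s1)NO` is not yet measured; it differs from compound 2 by the same change, (hydrogen in place of ethoxy on an aromatic carbon). The step of a 1.2-fold lower number from compound 3 to compound 1 (0.06 log units; within the scatter) stayed within the scatter, and the same change is made here. For compound 4 a similar small step is therefore expected, a 1.2-fold lower number from compound 2 to compound 4 (0.06 log units; within the scatter). Compound 4 is estimated at 6.9 ug/mL, with a likely range from 3.5 ug/mL to 14 ug/mL.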

Compound 4, half-maximal inhibitory concentration: 14.4 ug/mL
For compound 4 the middle estimate is 2.1-fold (0.32 log units) below the measured one; the measured number lies above the stated range.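

Putting hydrogen in place of ethoxy gives a 1.8-fold higher number from compound 2 to compound 4 (0.26 log units; within the scatter) in this assay, and this does not differ meaningfully from the same change made on the other core: the same change on two cores in this assay, a 1.2-fold lower number (0.06 log units; within the scatter) from compound 3 to compound 1 and a 1.8-fold higher number (0.26 log units; within the scatter) from compound 2 to compound 4, 2.1-fold (0.32 log units) apart, within the scatter of two such steps. Going by these compounds alone, putting hydroxycarbamoyl in place of 2-(hydroxycarbamoyl)ethyl gives a 2.5-fold higher number from compound 1 to compound 4 (0.40 log units; beyond the scatter), the only step here beyond the scatter, yet it too cannot be told apart from its counterpart: the same change on two cores in this assay, a 1.2-fold lower number (0.08 log units; within the scatter) from compound 2 to compound 3 and a 2.5-fold lower number (0.40 log units; beyond the scatter) from compound 4 to compound 1, 2.1-fold (0.32 log units) apart, within the scatter of two such steps. Both changes are therefore consistent across these cores, but two pairs per change cannot show that either step keeps the same size on other cores.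

Going by these compounds, it remains open how a methoxy group or a chlorine atom in place of the ethoxy would behave. On these data alone, the effect of a longer chain also remains open.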